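The source may report more compounds than this note shows. Statements on the series, on what has been measured and on what is new or still open speak of the compounds shown alone.

In the search for compounds that kill cancer cells, potency is often compared through a single cell-based test, here a functional assay on BT-549 cells (Homo sapiens) for cytotoxicity, read by MTT assay, with a stated time of 48 h; a higher number here means a weaker inhibitor, a lower number a stronger inhibitor. In this assay, within the data shown here, compound 1 `CC(C)n1c(/C=C2/C(=O)Nc3ccc(F)cc32)nc2ccccc21` gives 26700 nM, the only number available so far. Compound 2 `Cn1c(/C=C2/C(=O)Nc3ccc([N+](=O)[O-])cc32)nc2ccccc21` has no place on this scale, since the entry for compound 2 reads "not determined" (no result reported). No potency can therefore be stated for it, and it offers no baseline to measure a change from.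

The next compound, compound 3 `Cn1c(/C=C2/C(=O)Nc3ccc(F)cc32)nc2ccccc21`, differs from compound 2 at one point: fluoro in place of nitro on an aromatic carbon. In words, this is fluoro in place of nitro on an aromatic carbon. Among the measured compounds shown here, with no number for compound 2, the size of this swap cannot be read from the data, and no measured step between two compounds is available as a guide. The best remaining reference is compound 1, which also carries fluoro and gives 26700 nM. In this assay, a result for compound 3 is expected to fall close to that reference, with no shift in either direction beyond the usual scatter. Compound 3 is estimated at 30000 nM, with an expected range of 10000 nM to 85000 nM.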

Compound 3, half-maximal inhibitory concentration: 26900 nM
Compound 3: the middle estimate sits 1.1-fold (0.05 log units) above what was measured; the range from low to high includes it.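

In this assay the change is a 1.0-fold higher number from compound 1 to compound 3 (0.00 log units; within the scatter) and replaces isopropyl with methyl on the aromatic nitrogen while fluoro stays in place. Among these compounds, this pair is the first direct comparison at this position, and it shows that the two groups cannot be told apart here, a point that the single number for compound 1 could not settle. The swap of nitro for fluoro between compound 2 and compound 3 still cannot be read, as compound 2 has no number, and no measurement at hand offers an explanation for any of these results.

Methyl and isopropyl are the only groups with a number at this nitrogen, so it remains open whether a longer chain such as n-butyl, or a chain ending in an amine, would also leave the reading unchanged. Among the compounds shown here, on the aromatic carbon fluoro is the only group with a reading, which leaves open how a methoxy group or a carboxylic acid there would compare with compound 3.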